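The source may report more compounds than this note shows. Statements on the series, on what has been measured and on what is new or still open speak of the compounds shown alone.

In an ADME assay on cells (Hepatocyte, Rattus norvegicus) for metabolic stability (a lower number here means that the compound disappears faster, a higher number that the compound lasts longer), compound 1 `O=C(C1CCN(c2ncccn2)CC1)N1N=CC[C@H]1c1ccccc1` gives 0.137 h, while compound 2 `Cc1nnc(N2CCC(C(=O)N3N=CC[C@H]3c3ccccc3)CC2)o1` gives 2.88 h, the higher of the two numbers. Among the measured compounds shown here, one measured step bears on the next change: a 21-fold higher number from compound 1 to compound 2 (1.32 log units; beyond the scatter), a large step beyond the scatter, with 5-methyl-1,3,4-oxadiazol-2-yl in place of pyrimidin-2-yl on an amine nitrogen in a ring. Compound 3 `CC(=O)N1CCC(C(=O)N2N=CC[C@H]2c2ccccc2)CC1` changes that same place, with acetyl in place of 5-methyl-1,3,4-oxadiazol-2-yl on an amine nitrogen in a ring. For the measured compounds named here, the single earlier step shows that this assay can respond strongly to the group at this place, but it gives no direction for acetyl, which has no ring. No step beyond the scatter is therefore expected, although a sizeable move either way remains possible. The expected change is a 1.4-fold lower number from compound 2 to compound 3 (0.16 log units; within the scatter). Compound 3 is estimated at 2 h, with an expected range from 0.5 h to 6 h.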

Compound 3, half-life: > 3.11 h
Compound 3 ended at the assay's limit (the forecaster's own chance of this, stated with the estimate: 10%); middle value at least 1.5-fold (0.19 log units) from the limit.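

In this assay the result for compound 3 is a limit and not a number: the limit of > 3.11 h in this assay, at which 1 of the 3 values shown sits. Acetyl in place of pyrimidin-2-yl gives an at least 22-fold higher number from compound 1 to compound 3 (1.35 log units; beyond the scatter), so the large rise at this amine nitrogen does not depend on a five-membered aromatic ring, since acetyl has no ring and still shares that rise. The other step, an at least 1.0-fold higher number from compound 2 to compound 3 (0.03 log units; that floor lies within the scatter), has a floor within the scatter, so acetyl and 5-methyl-1,3,4-oxadiazol-2-yl cannot yet be put in order.

As far as these compounds go, how far compound 3 lies past the limit stays open, and with it whether acetyl lasts longer than the oxadiazole group. Also open, from the compounds shown here alone, is whether the short half-life of compound 1 belongs to pyrimidin-2-yl alone, or whether pyridin-2-yl or a plain methyl on this nitrogen would behave likewise.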